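The compounds below may be only part of what the source reports. "The series", "measured", "known", "first", "only" and "open" are said of these compounds alone.

Compound 1, `CC(C)C[C@@H]1NC(=O)[C@H](CCCNC(N)=O)NC(=O)[C@H](CCCCN)NC(=O)[C@H](CC(=O)O)NC(=O)[C@H](CCCCN)NC(=O)CCNC1=O`: in an assay on COS-7 cells for inhibition of disintegrin and metalloproteinase domain-containing protein 8 (Homo sapiens), read by ELISA, with a stated time of 6 h (on this read-out lower numbers stand for stronger inhibition and higher numbers for weaker inhibition), compound 1 gives 890 nM.
Compound 2, `CC(C)(C)C[C@@H]1NC(=O)[C@H](CCCNC(=N)N)NC(=O)[C@H](CCCCN)NC(=O)[C@H](CC(=O)O)NC(=O)[C@H](CCCCN)NC(=O)CCNC1=O`: in this assay compound 2 gives 256 nM.

Of these two, compound 2 has the lower number, and its gap to compound 1 lies beyond the usual scatter; the two compounds differ in more than one place, so no single change can be tied to that gap. Compound 3, `CCC[C@@H]1NC(=O)[C@H](CCCNC(=N)N)NC(=O)[C@H](CCCCN)NC(=O)[C@H](CC(=O)O)NC(=O)[C@H](CCCCN)NC(=O)CCNC1=O`, keeps everything in compound 2 except one change: ethyl in place of tert-butyl on a saturated chain carbon bound to a saturated ring carbon. Within the data shown here, no measured pair isolates this change, so the expectation rests only on the shrinking of that side chain; a modest move toward a higher number in this assay is expected, a 2.3-fold higher number from compound 2 to compound 3 (0.37 log units; beyond the scatter). Compound 3 is therefore estimated at 600 nM, within a range from 200 nM to 2000 nM.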

Compound 3, half-maximal inhibitory concentration: 452 nM
The estimate for compound 3 lay 1.3-fold (0.12 log units) above the measured number, within the range that was stated.
By their numbers in this assay, from the lowest: compounds 2, 3 and 1 (each within the scatter of the next, the first and the last beyond it).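

Putting ethyl in place of tert-butyl on a saturated chain carbon bound to a saturated ring carbon gives a 1.8-fold higher number from compound 2 to compound 3 (0.25 log units; within the scatter) in this assay. Among these compounds, this is the first comparison that isolates this position, and compound 2 and compound 3 cannot be told apart on this read-out, so here the side chain can go from tert-butyl to ethyl without a change beyond the scatter. Nothing measured here gives a reason for this result. Still open, on these data alone, is how a longer chain, such as hexyl, would read at this position, and whether a phenyl ring, an amine or a carboxylic acid there would shift the number beyond the scatter.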